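The compounds below may be only part of what the source reports. "The series", "measured", "known", "first", "only" and "open" are said of these compounds alone.

In a functional assay on Right cardiac atrium for agonist activity at histamine H2 receptor (Cavia porcellus), with a stated time of 30 min, in the presence of a further agent that is not named here (a lower number here means that less compound is needed, a higher number that more compound is needed for the effect), compound 3 `Cc1ccc(C(C)NC(=O)/N=C(\N)NCCCc2sc(N)nc2C)cc1` gives 22.4 nM, the lowest number among the three measured compounds. Compound 1 `COc1ccc(C(C)NC(=O)/N=C(\N)NCCCc2sc(N)nc2C)cc1` gives 38 nM, and compound 2 `Cc1nc(N)sc1CCCN/C(N)=N/C(=O)NC(C)c1ccc(Br)cc1` gives 55 nM. The step of a 1.7-fold lower number from compound 1 to compound 3 (0.23 log units; within the scatter) lies within the scatter, whereas a 2.5-fold lower number from compound 2 to compound 3 (0.39 log units; beyond the scatter) is modest but beyond it. Compound 4 `Cc1nc(N)sc1CCCN/C(N)=N/C(=O)NC(C)c1ccco1` differs from compound 3 by furan-2-yl in place of 4-methylphenyl on a saturated chain carbon bound to an amide-type nitrogen and a saturated chain carbon. Among the compounds with values here, none of the measured steps touches this site: each only exchanges one group for another on an aromatic carbon, and a 1.4-fold higher number from compound 1 to compound 2 (0.16 log units; within the scatter) was as small as the rest. These small steps lead to the expectation of a 1.8-fold higher number from compound 3 to compound 4 (0.25 log units; within the scatter), toward a somewhat higher number. Compound 4 is therefore estimated at 40 nM, within a range from 15 nM to 110 nM.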

Compound 4, half-maximal effective concentration: 9.77 nM
The estimate for compound 4 lay 4.1-fold (0.61 log units) above the measured number; the measured number lies below the stated range.
By their numbers in this assay, from the lowest: compound 4; then compounds 3, 1 and 2 (each within the scatter of the next, the first and the last beyond it).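

At this saturated chain carbon, a phenyl ring is not needed for a low number in this assay: furan-2-yl gives a 2.3-fold lower number from compound 3 to compound 4 (0.36 log units; beyond the scatter) and a 3.9-fold lower number from compound 1 to compound 4 (0.59 log units; beyond the scatter) and also a 5.6-fold lower number from compound 2 to compound 4 (0.75 log units; beyond the scatter) here. Each of the three substituted phenyl groups thus gives way to the five-membered ring in the same direction, leaving compound 4 with the lowest number of the four. The compounds shown leave open whether the ring oxygen of furan-2-yl matters, and how thiophen-2-yl or cyclohexyl would read at this carbon. No measurement shown here accounts for the change.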